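This account rests on a few compounds, and the source may have more. Where it says the series, first, only, none or still open, it means among the compounds named here.

Going by the values given here, compound 2, `Nc1nc(Cl)c2ncn(Cc3ccccc3CCl)c2n1`, sits at the high end of the three numbers measured so far in a functional assay on HOP-62 cells (Homo sapiens) for cytotoxicity, read by sulforhodamine B assay, with a stated time of 48 h; on this read-out higher numbers stand for weaker inhibition of growth and lower numbers for stronger inhibition of growth. In this assay compound 2 gives 21900 nM. Compound 3, `ClCc1ccccc1Cn1cnc2ncnc(Cl)c21`, gives 11200 nM, a number within the usual scatter of that of compound 2, so the two cannot be told apart. Compound 1, `ClCc1cccc(Cn2cnc3c(Cl)nc(Cl)nc32)c1`, gives 2290 nM, a clearly lower number than compound 2 shows, which here means stronger inhibition of growth.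

Compound 4, `ClCc1ccccc1Cn1cnc2c(Cl)ncnc21`, is the next compound to be measured. It differs from compound 2 in one place: hydrogen in place of amino on an aromatic carbon. Among the compounds with values here, no pair among the measured compounds differs by just this change, so nothing directly tells how large a step to expect. The lower numbers of compound 3 and compound 1, both lacking the amino group, suggest the step from compound 2 to compound 4 is expected to go toward a lower number, estimated at a 2.7-fold lower number from compound 2 to compound 4 (0.44 log units; beyond the scatter). For compound 4 the estimated value is 8000 nM, with an expected range from 2500 nM to 25000 nM.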

Compound 4, concentration for 50% growth inhibition: 2510 nM
The estimate for compound 4 lay 3.2-fold (0.50 log units) above the measured number; the range from low to high includes it.
By their numbers in this assay, from the lowest: compounds 1 and 4 (each within the scatter of the next); then compounds 3 and 2 (each within the scatter of the next).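

In this assay, putting hydrogen in place of amino on the aromatic carbon between two ring nitrogen atoms gives an 8.7-fold lower number from compound 2 to compound 4 (0.94 log units; beyond the scatter) and this step lies beyond the usual scatter, in the direction of stronger inhibition of growth. Going by these compounds alone, it is the first direct reading of this change, since no earlier pair differed in this one place alone. It shows that what this carbon carries matters for growth inhibition in these cells, at least within this single pair. Nothing available explains why the number falls with this change. On these data alone, whether a methyl or a methoxy group on this carbon would give a number nearer that of compound 4 or that of compound 2 stays open. Also open, as far as these compounds go, is whether the amino group has a similar effect when the chloromethyl group sits elsewhere on the benzene ring.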